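Benzyl ester in place of methyl ester on the nitrogen chain

The compounds below may be only part of what the source reports. "The series", "measured", "known", "first", "only" and "open" are said of these compounds alone.

Compound 1 `COc1ccc(-c2cc3c(OC)cc(OC)cc3n(C)c2=O)cc1`, compound 2 `CCOC(=O)Cn1c(=O)c(-c2ccc(OC)cc2)cc2c(OC)cc(OC)cc21` and compound 3 `COC(=O)CCn1c(=O)c(-c2ccc(OC)cc2)cc2c(OC)cc(OC)cc21` share one core and differ only in the chain on the ring nitrogen. In a functional assay on MCF7 cells (Homo sapiens) for cytotoxicity, read by colorimetric assay and MTT assay (a higher number here means a weaker inhibitor, a lower number a stronger inhibitor), compound 1 gives 10000 nM, compound 2 gives 10000 nM and compound 3 gives 10000 nM. The three steps among them, no change at the digits printed from compound 1 to compound 2 (within the scatter), no change at the digits printed from compound 1 to compound 3 (within the scatter) and no change at the digits printed from compound 2 to compound 3 (within the scatter), all stay within the scatter, so compound 3 stands level with compound 1 and compound 2 and nothing in this set separates the chains from one another.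

Compound 4 `COc1ccc(-c2cc3c(OC)cc(OC)cc3n(CCC(=O)OCc3ccccc3)c2=O)cc1` is the next member. It differs from compound 3 by phenyl in place of hydrogen on a saturated chain carbon bound to an oxygen next to a carbonyl group; read one bond further out, this is methoxycarbonyl to benzyloxycarbonyl on the same chain. For the measured compounds named here, no measured step touches the ester alcohol part directly; the steps that bear on it are the three above, each of which altered the chain on the ring nitrogen, including its ester, and each of which left this assay unchanged. The expectation is therefore a step of no change at the digits printed from compound 3 to compound 4 (within the scatter), none beyond the scatter. Compound 4 is estimated at 10000 nM, with a range from 4000 nM to 25000 nM.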

Compound 4, half-maximal inhibitory concentration: 10000 nM
Beside the measured number, compound 4's estimate shows no gap at the digits printed; low and high end bracket the measured number.
By their numbers in this assay, from the lowest: compounds 1, 2, 3 and 4 (each within the scatter of the next).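

In this assay, for the compounds shown here, the one step here confined to the alcohol part of the ester, phenyl in place of hydrogen on a saturated chain carbon bound to an oxygen next to a carbonyl group, gives no change at the digits printed from compound 3 to compound 4 (within the scatter) and so extends the flat reading from the chain on the ring nitrogen out to the ester's far end. The wider comparisons agree (no change at the digits printed from compound 2 to compound 4 (within the scatter); no change at the digits printed from compound 1 to compound 4 (within the scatter)), so the benzyloxycarbonyl chain, with its six added carbon atoms in one aromatic ring, is not separated from any other chain in this set. Nothing available here bears on the reason for this flat reading.

Still open, from the compounds shown here alone, is whether a free carboxylic acid at the end of the chain, an amide in place of the ester, a terminal amine or a longer chain would move the reading in this assay at all. Also open is whether a chlorine or methoxy substituent on the new phenyl ring would separate any compound from the four shown.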